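Two anilinopyrimidines and a change of aryl substituent

The compounds below may be only part of what the source reports. "The series", "measured", "known", "first", "only" and "open" are said of these compounds alone.

Compound 1, `COC(=O)CN(C)c1nc(Nc2ccc(Cl)cc2)ncc1[N+](=O)[O-]`, was examined in a functional assay on MCF7 cells (Homo sapiens) for antiproliferative activity, read by MTT assay, with a stated time of 48 h (on this read-out lower numbers stand for stronger inhibition and higher numbers for weaker inhibition), where compound 1 gives 60700 nM. Compound 2, `COC(=O)CN(C)c1nc(Nc2cccc(OC)c2)ncc1[N+](=O)[O-]`, differs from it by a single exchange, (3-methoxyphenyl in place of 4-chlorophenyl on a nitrogen on an aromatic ring). In this assay compound 2 gives 93700 nM. The step between them is a 1.5-fold higher number from compound 1 to compound 2 (0.19 log units; within the scatter).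

Compound 3, `CCOC(=O)CN(Cc1ccccc1)c1nc(Nc2ccc(Cl)cc2)ncc1[N+](=O)[O-]`, carries the same 4-chlorophenyl group as compound 1 on a core that differs in more than one place; the difference between the two cores is not broken down here. In this assay compound 3 reaches only a limit of the assay, > 100000 nM, and no number. This is the limit of > 100000 nM in this assay, at which 1 of the 3 values shown sits.

Compound 4, `CCOC(=O)CN(Cc1ccccc1)c1nc(Nc2cccc(OC)c2)ncc1[N+](=O)[O-]`, has not yet been measured. It stands to compound 3 as compound 2 stands to compound 1, differing by 3-methoxyphenyl in place of 4-chlorophenyl on a nitrogen on an aromatic ring. The place of the exchange reads the same in both pairs, so this is the same change made on a second core, and among the compounds shown it occurs twice in all.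

For compound 4 the account rests on two things: the earlier step of a 1.5-fold higher number from compound 1 to compound 2 (0.19 log units; within the scatter), which lay within the scatter, and the fact that compound 3 already sits at > 100000 nM. The step is expected to be a step that the limit leaves unreadable from compound 3 to compound 4. Compound 4 is accordingly expected to give about 150000 nM, between 80000 nM and 400000 nM, most likely again reported as a limit rather than a number.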

Compound 4, half-maximal inhibitory concentration: > 100000 nM
Compound 4: only a limit was reported; the forecaster's own chance of this, stated with the estimate: 80%; the middle value lies beyond the limit too.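

Compound 4, like compound 3, reaches only a limit of the assay, so no new step can be read for 3-methoxyphenyl in place of 4-chlorophenyl on this second core: the limit of > 100000 nM in this assay, at which 2 of the 4 values shown sit.

The compounds shown leave open how far apart compound 3 and compound 4 truly lie, and whether the exchange behaves on this core as it does on the core of compound 1.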